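Side-chain swap at the amino substituent of compound 2

The source may report more compounds than this note shows. Statements on the series, on what has been measured and on what is new or still open speak of the compounds shown alone.

Measured compounds:
compound 1, `CSc1nc(NCc2ccccc2)c2c(n1)C(=O)C(c1ccccc1)=[N+]2[O-]` — 27000 nM in a functional assay on HBL-100 cells (Homo sapiens) for antiproliferative activity, read by sulforhodamine B assay, with a stated time of 48 h; a lower number here means a stronger inhibitor of growth, a higher number a weaker inhibitor of growth
compound 2, `Nc1nc(NCc2ccccc2)nc2c1[N+]([O-])=C(c1ccccc1)C2=O` — 5100 nM in this assay

Compound 2 holds the lowest of the two numbers in this assay; compound 1 gives 27000 nM, and the gap between the two values lies beyond the scatter. Compound 1 and compound 2 differ in more than one place, so no single-point step can be read between them.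

Compound 3, `Nc1nc(NCCN2CCCC2)nc2c1[N+]([O-])=C(c1ccccc1)C2=O`, is the next compound in the series. Its change from compound 2 is (pyrrolidin-1-yl)methyl in place of phenyl on a saturated chain carbon bound to a nitrogen on an aromatic ring. Among the measured compounds shown here, no step between measured compounds describes a change of this kind, so nothing in the data fixes its size or direction.

With the core of compound 2 kept intact, compound 3 is expected to stay close to compound 2, with the step from a 1.3-fold lower number from compound 2 to compound 3 (0.11 log units; within the scatter) estimated as small and not clearly beyond the scatter. Compound 3 is therefore estimated at 4000 nM in this assay, within a range of 1200 nM to 15000 nM.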

Compound 3, concentration for 50% growth inhibition: 1800 nM
Compound 3: middle estimate off by 2.2-fold (0.35 log units), on the high side, and the stated range covers the measured number.
By their numbers in this assay, from the lowest: compound 3; then compound 2; then compound 1.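

Among the compounds shown here, on the saturated chain carbon bound to a nitrogen on an aromatic ring, (pyrrolidin-1-yl)methyl in place of phenyl gives a 2.8-fold lower number from compound 2 to compound 3 (0.45 log units; beyond the scatter) in this assay, the first single-point step that can be read. In this pair the phenyl is not required for growth inhibition, and a non-aromatic ring with a hetero atom gives the lower number. Nothing available bears on the reason for this step.

Still open, from the compounds shown here alone, is whether the step belongs to the pyrrolidine nitrogen or to the loss of the phenyl; a 2-cyclopentylethyl or 2-phenylethyl group at this place would separate the two. Also open, going by these compounds, is how a piperidine, a morpholine or a longer chain between the amino nitrogen and the pyrrolidine would read.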